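The source may report more compounds than this note shows. Statements on the series, on what has been measured and on what is new or still open speak of the compounds shown alone.

Of the compounds shown here, three that share one core have been tested in a functional assay on M21 cells (Homo sapiens) for antiproliferative activity, read by sulforhodamine B assay, with a stated time of 48 h; a lower number here means a stronger inhibitor, a higher number a weaker inhibitor. Compound 1 `O=C1NCCN1c1ccc(S(=O)(=O)Nc2ccc(F)c(F)c2)cc1` gives 220 nM, compound 2 `COc1ccccc1NS(=O)(=O)c1ccc(N2CCNC2=O)cc1` gives 300 nM, and compound 3 `O=C1NCCN1c1ccc(S(=O)(=O)Nc2cccc(Cl)c2)cc1` gives 25 nM, the lowest number of the three, beyond the scatter from both others. The step of an 8.8-fold lower number from compound 1 to compound 3 (0.94 log units; beyond the scatter) and the step of a 12-fold lower number from compound 2 to compound 3 (1.08 log units; beyond the scatter) both show that the group on the sulfonamide nitrogen matters, and that 3-chlorophenyl gave the lowest number seen. Compound 4 `Cc1ccc(C)c(NS(=O)(=O)c2ccc(N3CCNC3=O)cc2)c1` alters that same group: 2,5-dimethylphenyl in place of 3-chlorophenyl on a sulfonamide nitrogen. A higher number is expected for compound 4, because the steps of an 8.8-fold lower number from compound 1 to compound 3 (0.94 log units; beyond the scatter) and a 12-fold lower number from compound 2 to compound 3 (1.08 log units; beyond the scatter) both fell when 3-chlorophenyl came in. The expected step is a 6.0-fold higher number from compound 3 to compound 4 (0.78 log units; beyond the scatter). Compound 4 is therefore estimated at 150 nM in this assay, within a range from 40 nM to 600 nM.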

Compound 4, half-maximal inhibitory concentration: 27 nM
The estimate for compound 4 lay 5.6-fold (0.74 log units) above the measured number, outside the stated range (below it).
By their numbers in this assay, from the lowest: compounds 3 and 4 (each within the scatter of the next); then compounds 1 and 2 (each within the scatter of the next).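

The step of a 1.1-fold higher number from compound 3 to compound 4 (0.03 log units; within the scatter) shows that 2,5-dimethylphenyl on the sulfonamide nitrogen matches 3-chlorophenyl, so chlorine is not required for a low number at this position. The steps of an 11-fold lower number from compound 2 to compound 4 (1.05 log units; beyond the scatter) and an 8.1-fold lower number from compound 1 to compound 4 (0.91 log units; beyond the scatter) show that 2,5-dimethylphenyl also shares the advantage of 3-chlorophenyl over the other two substituted phenyl groups. No supporting data here explain these differences.

Going by these compounds, whether both methyl groups of compound 4 are needed remains open. So does whether an amine or a carboxylic acid on this phenyl ring would keep the number this low.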